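Swapping a piperazine substituent and its effect on exposure

The compounds below may be only part of what the source reports. "The series", "measured", "known", "first", "only" and "open" are said of these compounds alone.

Compound 1 `COc1ccc2c(c1)C(=O)N(C[C@]1(c3cc4ncccc4o3)C(=O)N(COC(=O)C(C)(C)C)C(=O)N1COC(=O)C(C)(C)C)C2` gives 1920 ng.h/mL in an ADME assay on the whole organism for pharmacokinetics, with Rattus norvegicus as the target, read by LC-MS, at a dose of 10 mg/kg by the oral route; a lower number here means less compound in the circulation, a higher number more compound in the circulation at the dose given. Compound 2 `CCOP(=O)(OCC)OCN1C(=O)N[C@@](CN2Cc3ccc(OC)cc3C2=O)(c2cc3ncccc3o2)C1=O` gives 27.9 ng.h/mL. Compound 3 `CCN1CCN(c2ccc3oc([C@]4(CN5Cc6ccc(OC)c(F)c6C5=O)NC(=O)N(COC(=O)C(C)(C)C)C4=O)cc3n2)CC1` gives 12700 ng.h/mL.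

Among these three, compound 3 stands highest in this assay; the gap to compound 1 lies beyond the scatter, and the gap to compound 2 is wider still. Within the data shown here, no pair of these measured compounds differs in only one place, so no single change can be read off against a single step in this assay.

Compound 4 `COc1ccc2c(c1F)C(=O)N(C[C@@]1(c3cc4nc(N5CCNC(=O)C5)ccc4o3)NC(=O)N(COC(=O)C(C)(C)C)C1=O)C2` follows from compound 3 by one change: 3-oxopiperazin-1-yl in place of 4-ethylpiperazin-1-yl on an aromatic carbon. The rest of the molecule, including the pivaloyloxymethyl group and the fluorinated isoindolinone side, is kept.

Among the measured compounds shown here, with no measured step of this kind to lean on, the expectation for compound 4 in this assay rests on compound 3 alone, whose 12700 ng.h/mL sets the starting point. A step of moderate size downward is expected from compound 3 to compound 4, a 2.5-fold lower number from compound 3 to compound 4 (0.40 log units; beyond the scatter), and it is not certain to fall beyond the scatter. Compound 4 is therefore estimated at 5000 ng.h/mL, with a range from 1500 ng.h/mL to 15000 ng.h/mL.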

Compound 4, area under the concentration-time curve: 374 ng.h/mL
Beside the measured number, compound 4's estimate is 13-fold (1.13 log units) above it; the measured number lies below the stated range.
By their numbers in this assay, from the lowest: compound 2; then compound 4; then compound 1; then compound 3.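

Among these compounds, this step is the first that can be read at a single place, on the aromatic carbon next to the ring nitrogen, with the pivaloyloxymethyl group and the fluorinated isoindolinone side held the same. In this assay the change to 3-oxopiperazin-1-yl in place of 4-ethylpiperazin-1-yl gives a 34-fold lower number from compound 3 to compound 4 (1.53 log units; beyond the scatter) and so shows that this position strongly affects the number, even though both groups hold a six-membered non-aromatic ring with 2 hetero atoms and carry no net charge. Nothing at hand accounts for the size of this step, which comes with a carbonyl and 1 hydrogen-bond donor entering and an ethyl group leaving.

The compounds shown leave open which of these differences matters, and a plain piperazin-1-yl with its free amine, a 4-methylpiperazin-1-yl or a morpholine at this place would help to separate them. Going by these compounds, it also remains open whether a step of this size would hold on the core of compound 2, with its diethyl phosphate group in place of the pivaloyloxymethyl group.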